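Does a ring at this place keep the low number?

This account rests on a few compounds, and the source may have more. Where it says the series, first, only, none or still open, it means among the compounds named here.

Measured in a functional assay with Oryctolagus cuniculus as the target; a lower number here means a stronger inhibitor, a higher number a weaker inhibitor:
- Compound 1 `COc1ccc(-c2nc(/N=C(\N)NC(C)C)sc2-c2ccc(OC)cc2)cc1`: > 100 nM (a limit of the assay, not a number)
- Compound 2 `CNC(=O)NCc1nc(-c2ccc(OC)cc2)c(-c2ccc(OC)cc2)s1`: 22 nM
- Compound 3 `CCOC(=O)/C=C/c1nc(-c2ccc(OC)cc2)c(-c2ccc(OC)cc2)s1`: 20 nM

Compound 3 shares the low end of these values with one partner, as a 1.1-fold lower number from compound 2 to compound 3 (0.04 log units; within the scatter) shows. Compound 1 gives only a limit, (the limit of > 100 nM in this assay, at which 1 of the 3 values shown sits). This place on the shared core is not indifferent, however: an at least 4.5-fold lower number from compound 1 to compound 2 (0.65 log units; beyond the scatter), and an at least 5.0-fold lower number from compound 1 to compound 3 (0.69 log units; beyond the scatter).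

Compound 4 `COc1ccc(-c2nc(C3=NNC(=O)CC3)sc2-c2ccc(OC)cc2)cc1` carries its change at the same place, where 2-(ethoxycarbonyl)ethenyl leaves: a group of 7 heavy atoms (4 carbon, 2 nitrogen, 1 oxygen; one six-membered non-aromatic ring with 2 hetero atoms) in place of a group of 7 heavy atoms (5 carbon, 2 oxygen; no ring), on an aromatic carbon. Going by the values given here, no measured compound has a ring here, so the steps give only indirect guidance. Unlike groups can match here, as a 1.1-fold lower number from compound 2 to compound 3 (0.04 log units; within the scatter) shows, but the steps away from the limit show that a swap can also cost. The expectation in this assay is a modest move toward a higher number, an estimated 2.0-fold higher number from compound 3 to compound 4 (0.30 log units; within the scatter). The number for compound 4 is estimated at 40 nM, with an expected range from 8 nM to 200 nM.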

Compound 4, half-maximal inhibitory concentration: > 1000 nM
Compound 4: no number, only a limit; the forecaster's own chance of this, stated with the estimate: 20%; middle value at least 25-fold (1.39 log units) from the limit.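

In this assay compound 4 gives > 1000 nM, which is a limit of the assay and not a number. This ring does not keep the low number, with an at least 50-fold higher number from compound 3 to compound 4 (1.69 log units; beyond the scatter) and an at least 45-fold higher number from compound 2 to compound 4 (1.65 log units; beyond the scatter), so the two unlike open-chain groups that match here give no assurance for a ring. The leaving and entering groups have equal counts of heavy atoms and of double bonds outside aromatic rings, so those counts alone do not set the number, while the step between compound 1 and compound 4 cannot be read, with a limit at each end.

Nothing measured here explains the loss. Going by these compounds, whether the ring as such or its hydrogen-bond donor goes with the loss stays open, and a morpholine ring or a phenyl ring at this place would help to separate the two.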